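Aminoquinone series: from azetidinyl to arylamino

The source may hold more compounds than are shown below. What is called first, only, known or untested is meant among the compounds shown, and "the series" means these compounds.

- Compound 1 `O=C1C(N2CCCCC2)=CC(=O)c2c1nc1n2[C@H]2OC[C@@H](O)[C@H]2OC1`: > 8000 nM
- Compound 2 `O=C1C(N2CCC2)=CC(=O)c2c1nc1n2[C@H]2OC[C@@H](O)[C@H]2OC1`: > 16000 nM
- Compound 3 `COc1cccc(NC2=CC(=O)c3c(nc4n3[C@H]3OC[C@@H](O)[C@H]3OC4)C2=O)c1`: not yet measured

All values come from a functional assay on MCF7 cells (Homo sapiens) for inhibition, read by sulforhodamine B assay; a lower number here means a stronger inhibitor, a higher number a weaker inhibitor. Compound 1 gives > 8000 nM, which is a limit and not a number. Compound 2 gives > 16000 nM, which is also a limit and not a number. Among the measured compounds shown here, the series therefore has no numeric value so far.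

Compound 3 carries (3-methoxyphenyl)amino in place of azetidin-1-yl on a double-bonded ring carbon of the core of compound 2: (3-methoxyphenyl)amino in place of azetidin-1-yl on a double-bonded ring carbon.

For the measured compounds named here, the only measured step is a step that the two limits leave unreadable from compound 1 to compound 2, so it offers no size to carry forward. Going by the values given here, no measured compound carries the entering group. The expectation in this assay is therefore weakly founded, and a further limit is quite possible for compound 3. The expected step is an at least 1.6-fold lower number from compound 2 to compound 3 (0.20 log units; that floor lies within the scatter), towards a stronger inhibitor. The estimate for compound 3 is 10000 nM, with an expected range from 3000 nM to 30000 nM.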

Compound 3, half-maximal inhibitory concentration: 3830 nM
Compound 3: middle estimate off by 2.6-fold (0.42 log units), on the high side; low and high end bracket the measured number.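

In this assay, among the compounds shown here, compound 3 is the first member of the series to give a number, 3830 nM, so this double-bonded ring carbon can carry a group that yields a readable value. Azetidin-1-yl and piperidin-1-yl yielded only limits there. Bringing in (3-methoxyphenyl)amino gives an at least 4.1-fold lower number from compound 2 to compound 3 (0.62 log units; beyond the scatter) and an at least 2.0-fold lower number from compound 1 to compound 3 (0.31 log units; beyond the scatter); both are floors, so the true size of each change may be larger, and the change in the entering group is a broad one, with an aromatic ring, a methoxy group and a hydrogen-bond donor arriving together. The larger floor is set by compound 2, whose value is a limit of the assay and not a number: the limit of > 16000 nM in this assay, at which 1 of the 3 values shown sits.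

The step between the two limits cannot be read, so piperidin-1-yl and azetidin-1-yl cannot be ranked against each other. Which part of (3-methoxyphenyl)amino carries the gain stays open, and a plain phenylamino group, which lacks the methoxy, or a benzylamino group, with a carbon inserted before the ring, would separate these parts on the same core.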